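Trimming the Amide Side Chain of Compound 2

This account rests on a few compounds, and the source may have more. Where it says the series, first, only, none or still open, it means among the compounds named here.

Compound 1 (`CCn1c(C(=O)N(CCC#N)CCC#N)ccc1C(CC)(CC)c1ccc(OCCC(O)(CC)CC)c(C)c1`): in an assay on cells for agonist activity at vitamin D3 receptor (Homo sapiens), with a stated time of 96 h (on this read-out higher numbers stand for an effect only at larger amounts of compound and lower numbers for an effect already at smaller amounts), compound 1 reaches only the assay limit > 10000 nM.
Compound 2 (`CCC(C)C(CO)NC(=O)c1ccc(C(CC)(CC)c2ccc(OCCC(O)(CC)CC)c(C)c2)n1CC`): in this assay compound 2 gives 450 nM.

Within the data shown here, compound 2 holds the only actual number here; the other value is a limit, recorded as the limit of > 10000 nM in this assay, at which 1 of the 2 values shown sits. Among the measured compounds shown here, the single measured step, an at least 22-fold lower number from compound 1 to compound 2 (1.34 log units; beyond the scatter), replaced the whole group on a carbonyl carbon and was large. Compound 3 (`CCn1c(C(=O)NC(C)CO)ccc1C(CC)(CC)c1ccc(OCCC(O)(CC)CC)c(C)c1`) keeps that amide and changes less: methyl in place of sec-butyl on a saturated chain carbon bound to an amide-type nitrogen and a saturated chain carbon. For the measured compounds named here, no measured step trims only this sec-butyl, so the large step from compound 1 to compound 2 offers no direct guide. A smaller move is expected, plausibly toward a higher number, estimated as a 2.0-fold higher number from compound 2 to compound 3 (0.30 log units; within the scatter). For compound 3 the expected value in this assay is 900 nM, within 300 nM to 3000 nM.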

Compound 3, half-maximal effective concentration: 96 nM
For compound 3 the middle estimate is 9.4-fold (0.97 log units) above the measured one, outside the stated range (below it).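

In this assay, methyl in place of sec-butyl on a saturated chain carbon bound to an amide-type nitrogen and a saturated chain carbon gives a 4.7-fold lower number from compound 2 to compound 3 (0.67 log units; beyond the scatter), so the larger sec-butyl is not needed for an effect at this carbon. Exchanging the whole group on the carbonyl carbon for the smaller hydroxyl-bearing chain gives an at least 100-fold lower number from compound 1 to compound 3 (2.01 log units; beyond the scatter). Compound 1 is recorded only at a limit: the limit of > 10000 nM in this assay, at which 1 of the 3 values shown sits.

As far as these compounds go, with only sec-butyl and methyl compared at this carbon, it remains open whether an ethyl group or a plain hydrogen there would give a lower or a higher number. Compound 2 and compound 3 both carry the hydroxymethyl group, and a carboxylic acid or a methoxymethyl group in its place would be needed to show what that group contributes.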